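Trimming the phosphate chain on a purine nucleotide analogue

The source may report more compounds than this note shows. Statements on the series, on what has been measured and on what is new or still open speak of the compounds shown alone.

Three compounds share a purine-type core joined to a fused bicyclic sugar mimic carrying a chain of phosphate groups. Compound 1 `Nc1ncnc2c1ncn2C1C(O)C(O)C2(COP(=O)(O)OP(=O)(O)OP(=O)(O)O)CC12` gives 14 nM in an assay on cell membranes for activation of P2Y purinoceptor 1 (Meleagris gallopavo); a lower number here means that less compound is needed, a higher number that more compound is needed for the effect. Compound 2 `CSc1nc(N)c2ncn(C3C(O)C(O)[C@@]4(COP(=O)(O)OP(=O)(O)OP(=O)(O)O)C[C@@H]34)c2n1`, which adds a methylthio group to the core, reaches 3.7 nM in this assay. Compound 3 `CSc1nc(N)c2ncn([C@H]3[C@H](O)[C@H](O)[C@@]4(COP(=O)(O)OP(=O)(O)O)C[C@@H]34)c2n1`, with one phosphate fewer, gives 0.88 nM and so shows the lowest number of the three, beyond the scatter from both. Compound 4 `CSc1nc(N)c2ncn([C@H]3[C@H](O)[C@H](O)[C@@]4(COP(=O)(O)O)C[C@@H]34)c2n1` shortens the chain again: a hydrogen atom in place of a group of 4 heavy atoms (3 oxygen, 1 phosphorus; no ring), on an oxygen. Among the measured compounds shown here, no measured pair here follows exactly this change, so the expectation rests on the trend and is uncertain. Compound 4 is expected to need clearly more compound, a step of a 34-fold higher number from compound 3 to compound 4 (1.53 log units; beyond the scatter). Compound 4 is therefore estimated at 30 nM, within 5 nM to 300 nM.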

Compound 4, half-maximal effective concentration: 1190 nM
For compound 4 the middle estimate is 40-fold (1.60 log units) below the measured one; the whole stated range lies below it.
By their numbers in this assay, from the lowest: compound 3; then compound 2; then compound 1; then compound 4.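

On this oxygen, whose other neighbour is phosphorus, the group of 4 heavy atoms (3 oxygen, 1 phosphorus) matters greatly: putting a hydrogen atom in its place gives a 1400-fold higher number from compound 3 to compound 4 (3.13 log units; beyond the scatter) in this assay. Compound 4 therefore has the highest number of the four, so removing a phosphate does not lower the number at every chain length. Nothing available explains the size of this step. From the compounds shown here alone, whether a carboxylic acid or an amine in place of this group would keep the low number of compound 3 remains open.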